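The source may hold more compounds than are shown below. What is called first, only, known or untested is meant among the compounds shown, and "the series" means these compounds.

The measured compounds:

Compound 1, `CCOCc1cc(O)c(O)c(Br)c1Cc1cc(O)c(O)c(Br)c1Br`: 3400 nM
Compound 2, `Oc1cc(COCc2cc(O)c(O)c(Br)c2Br)c(Br)c(Br)c1O`: 21400 nM

In a functional assay on MCF7 cells (Homo sapiens) for cytotoxicity, read by MTT assay, with a stated time of 96 h (a higher number here means a weaker inhibitor, a lower number a stronger inhibitor), compound 1 gives 3400 nM and holds the lower of the two numbers. Compound 2 gives 21400 nM in this assay, a gap from compound 1 that lies beyond the usual scatter. For the measured compounds named here, no step between two measured compounds that differ in a single place is available, so the only guide for the next compound is the size of the change itself.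

Compound 3, `COCc1cc(O)c(O)c(Br)c1Cc1cc(O)c(O)c(Br)c1Br`, differs from compound 1 by hydrogen in place of methyl on a saturated chain carbon bound to an oxygen on a saturated carbon. This is a small change on a saturated chain carbon bound to an oxygen on a saturated carbon. Going by the values given here, with no measured pair of this kind to draw on, the account expects the step of a 1.2-fold higher number from compound 1 to compound 3 (0.07 log units; within the scatter) to stay within the scatter of this assay, in no firm direction. For compound 3 the estimate in this assay is 4000 nM, with a range from 1700 nM to 9500 nM.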

Compound 3, half-maximal inhibitory concentration: 4600 nM
Beside the measured number, compound 3's estimate is 1.2-fold (0.06 log units) below it; the range from low to high includes it.
By their numbers in this assay, from the lowest: compounds 1 and 3 (each within the scatter of the next); then compound 2.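

In this assay, for the compounds shown here, the change from ethoxymethyl to methoxymethyl gives a 1.4-fold higher number from compound 1 to compound 3 (0.13 log units; within the scatter), the first step here that isolates a single place on the shared core. At this position, on a saturated chain carbon bound to an oxygen on a saturated carbon, replacing methyl with hydrogen therefore leaves the number within the scatter, so this pair shows no measurable effect of that methyl. No measurement at hand explains why the two numbers stay so close.

This single pair cannot show whether the position stays as undemanding when the chain is changed more strongly, as with a longer chain, an amine or a carboxylic acid. It also leaves open whether the same change would behave alike on another core.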